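A few compounds are considered here, and "the series" means these few. Any claim that something is new, unique, unknown or untested is made for them only; others in the source may bear on it.

Of the compounds shown here, two have been measured in a functional assay on DU-145 cells (Homo sapiens) for inhibition, read by trypan blue exclusion, with a stated time of 96 h; a higher number here means a weaker inhibitor of growth, a lower number a stronger inhibitor of growth. Compound 1 `Cc1ccc(CS(=O)(=O)/C(=C/c2cccc(Cl)c2Cl)C(=O)c2ccc(Cl)cc2)cc1` gives 1000 nM, and compound 2 `Cc1ccsc1/C=C(\C(=O)c1ccc(Cl)cc1)S(=O)(=O)Cc1ccc(F)cc1` gives 10000 nM. Compound 2 therefore has the higher of the two numbers and is the weaker inhibitor of growth, and the gap between them lies beyond the usual scatter of repeated measurements.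

Compound 3 `Cc1ccc(CS(=O)(=O)/C(=C/c2sccc2C)C(=O)c2ccc(Cl)cc2)cc1` differs from compound 2 in one place: methyl in place of fluoro on an aromatic carbon. Put another way, 4-fluorobenzyl becomes 4-methylbenzyl. Among the compounds with values here, no measured pair isolates this change, so its effect cannot be read directly from the data. Within the data shown here, the only hint comes from compound 1, which carries 4-methylbenzyl and gives 1000 nM, but it also differs from compound 2 elsewhere, so the hint is weak. A modest move towards stronger inhibition is therefore expected, and no change beyond the scatter would also be plausible. The expected result is a 2.5-fold lower number from compound 2 to compound 3 (0.40 log units; beyond the scatter). For compound 3 the estimated value is 4000 nM, with an expected range from 1000 nM to 12000 nM.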

Compound 3, concentration for 50% growth inhibition: 25000 nM
Beside the measured number, compound 3's estimate is 6.3-fold (0.80 log units) below it, and the stated range ends below it.
By their numbers in this assay, from the lowest: compound 1; then compound 2; then compound 3.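

With the 3-methylthiophen-2-yl group unchanged, replacing 4-fluorobenzyl with 4-methylbenzyl gives a 2.5-fold higher number from compound 2 to compound 3 (0.40 log units; beyond the scatter) in this assay, so this position does respond to the swap of fluoro for methyl, and here methyl goes with weaker inhibition of growth, not stronger. With 4-methylbenzyl now held constant, the other site can also be read on its own: 3-methylthiophen-2-yl in place of 2,3-dichlorophenyl gives a 25-fold higher number from compound 1 to compound 3 (1.40 log units; beyond the scatter), a large step against the modest one at the benzyl group. No measurement here explains why either change has the effect it does.

From the compounds shown here alone, it remains open whether fluoro is the better of many possible groups at this position, or whether a chlorine, a methoxy group, an amine or a carboxylic acid on the same aromatic carbon would give a lower number still. Within the data shown here, it is also open whether methyl in place of fluoro would give a similar step in a compound carrying 2,3-dichlorophenyl, as the only step for this swap comes from compounds carrying 3-methylthiophen-2-yl.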